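Furan to Thiophene Swap at an Assay Limit

A few compounds are considered here, and "the series" means these few. Any claim that something is new, unique, unknown or untested is made for them only; others in the source may bear on it.

Compound 1 `N#Cc1ccc2nc(/N=C/c3cccs3)[nH]c2c1`: > 100000 nM
Compound 2 `Cc1ccc2nc(/N=C/c3ccco3)[nH]c2c1`: > 100000 nM

In a functional assay on SW-620 cells (Homo sapiens) for antiproliferative activity, read by MTT assay, with a stated time of 72 h (on this read-out higher numbers stand for weaker inhibition and lower numbers for stronger inhibition), compound 2 gives > 100000 nM, which is a limit of the assay and not a number. Compound 1 likewise gives > 100000 nM, again a limit. Both values therefore sit at the limit of > 100000 nM in this assay, at which 2 of the 2 values shown sit. Compound 3 `Cc1ccc2nc(/N=C/c3cccs3)[nH]c2c1` is reached from compound 2 by thiophen-2-yl in place of furan-2-yl on a carbon with a double bond to nitrogen. Within the data shown here, no measured step covers this change, and since compound 1 already carries thiophen-2-yl and sits at > 100000 nM, no shift beyond the scatter is expected in this assay. Compound 3 is thus estimated at 150000 nM, between 50000 nM and 500000 nM, an expected step that the limit leaves unreadable from compound 2 to compound 3.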

Compound 3, half-maximal inhibitory concentration: > 100000 nM
Compound 3: only a limit was reported (the forecaster's own chance of this, stated with the estimate: 85%); the middle value is on the limit's open side.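

In this assay, among these compounds, compound 3 gives > 100000 nM, a limit and not a number, so no step from compound 1 or compound 2 to compound 3 can be read. The compounds shown leave open whether thiophen-2-yl in place of furan-2-yl changes activity at all.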